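The source may report more compounds than this note shows. Statements on the series, on what has been measured and on what is new or still open speak of the compounds shown alone.

Measured so far in a functional assay on Mahlavu cells (Homo sapiens) for antiproliferative activity, read by sulforhodamine B assay, with a stated time of 72 h; on this read-out lower numbers stand for stronger inhibition and higher numbers for weaker inhibition:
compound 1 `Cc1cccc(COc2ccc(-c3cc(CN4CCN(Cc5ccc(C(F)(F)F)cc5)CC4)no3)cc2)c1`: 2500 nM
compound 2 `Fc1ccc(COc2ccc(-c3cc(CN4CCN(Cc5ccc(C(F)(F)F)cc5)CC4)no3)cc2)cc1`: 3100 nM

Both share a core and differ only in the aryl group on a saturated chain carbon bound to an oxygen on an aromatic ring. Within the data shown here, the single step measured, a 1.2-fold higher number from compound 1 to compound 2 (0.09 log units; within the scatter), is within the scatter, so the two numbers cannot be told apart. Among the measured compounds shown here, compound 2 therefore stands on the bare figures with compound 1 as its only neighbour and within the scatter of it; no ranking follows.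

Compound 3 `COc1cc(COc2ccc(-c3cc(CN4CCN(Cc5ccc(C(F)(F)F)cc5)CC4)no3)cc2)cc(OC)c1` is not yet measured. It differs from compound 2 by 3,5-dimethoxyphenyl in place of 4-fluorophenyl on a saturated chain carbon bound to an oxygen on an aromatic ring. For the measured compounds named here, the one step that bears on this position, a 1.2-fold higher number from compound 1 to compound 2 (0.09 log units; within the scatter), swapped the aryl group at the same place and left the number within the scatter. From the compounds shown here alone, nothing measured touches a 3,5-dimethoxyphenyl group, so its contribution is unknown and the range is set wide. Compound 3 is expected in this assay to show no step beyond the scatter, a 1.0-fold lower number from compound 2 to compound 3 (0.01 log units; within the scatter). Compound 3 is estimated at 3000 nM, between 1200 nM and 8000 nM.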

Compound 3, half-maximal inhibitory concentration: 4300 nM
Compound 3: the middle estimate sits 1.4-fold (0.16 log units) below what was measured, within the range that was stated.
By their numbers in this assay, from the lowest: compounds 1, 2 and 3 (each within the scatter of the next).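

In this assay, the change from 4-fluorophenyl to 3,5-dimethoxyphenyl on a saturated chain carbon bound to an oxygen on an aromatic ring replaces a group of 7 heavy atoms and 0 hydrogen-bond acceptors with one of 10 heavy atoms and 2 hydrogen-bond acceptors, yet the step stays within the scatter (a 1.4-fold higher number from compound 2 to compound 3 (0.14 log units; within the scatter)). The comparison with the 3-methylphenyl group is also within the scatter (a 1.7-fold higher number from compound 1 to compound 3 (0.24 log units; within the scatter)), so the three aryl groups now seen at this place cannot be told apart, and none of compounds 1, 2 and 3 goes against that reading. No measurement is available that would explain this lack of separation.

Still open, from the compounds shown here alone, is whether any group at this place can move the number beyond the scatter, for instance an amine or a carboxylic acid on the aryl ring, or a longer chain between the ring and the oxygen. All three compounds also keep the rest of the shared core unchanged, so the compounds shown say nothing about how changes elsewhere in the structure would read in this assay.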